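A few compounds are considered here, and "the series" means these few. Any claim that something is new, unique, unknown or untested is made for them only; others in the source may bear on it.

Compounds measured in a functional assay on CHO cells for inhibition of transient receptor potential cation channel subfamily V member 1 (Homo sapiens); on this read-out higher numbers stand for weaker inhibition and lower numbers for stronger inhibition:

Compound 1, `CN(C)CCC/C(=C\C(=O)Nc1ccc2c(c1)OCCO2)c1ccc(C(C)(C)C)cc1`, gives > 4000 nM; this is a limit of the assay and not a number.
Compound 2, `CC(C)(C)c1ccc(/C=C/C(=O)Nc2ccc3c(c2)NC(=O)CO3)cc1`, gives > 4000 nM; this too is a limit.
Compound 3, `O=C(/C=C/c1ccccc1)Nc1ccc2c(c1)OCCO2`, gives > 4000 nM; this again is a limit.

For the measured compounds named here, compound 3 therefore stands at no numbered position at all: its value is the limit of > 4000 nM in this assay, at which 3 of the 3 values shown sit, and no step between measured compounds can be read from these three results.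

Compound 4, `O=C(/C=C/c1ccc(F)cc1)Nc1ccc2c(c1)OCCO2`, differs from compound 3 by fluoro in place of hydrogen on an aromatic carbon. Since every measured value is a limit, there is no comparison within this series to lean on, and a change of this small size gives no reason to expect a large shift. The expected step from compound 3 to compound 4 in this assay is a step that the limit leaves unreadable from compound 3 to compound 4, which most likely leaves compound 4 at the same limit. The estimate for compound 4 in this assay is 6000 nM, with a range from 2000 nM to 20000 nM.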

Compound 4, half-maximal inhibitory concentration: > 4000 nM
Compound 4 ended at the assay's limit; the forecaster's own chance of this, stated with the estimate: 75%; the middle value lies beyond the limit too.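

No step can be read from compound 3 to compound 4, since both results are limits and not numbers: the limit of > 4000 nM in this assay, at which 4 of the 4 values shown sit.

With no numbered value among them, the compounds shown leave open what phenyl to 4-fluorophenyl, or any other structural difference here, does to inhibition in this assay.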